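This account rests on a few compounds, and the source may have more. Where it says the series, first, only, none or still open, it means among the compounds named here.

Working notes on this series.

Going by the values given here, compound 1 `COc1c(OCCCCN2CCNCC2)cc(O)c2c(=O)cc(-c3ccccc3)oc12` is the only member with a number in hand: in a functional assay on A549 cells (Homo sapiens) for cytotoxicity, read by MTT assay, with a stated time of 48 h (a higher number here means a weaker inhibitor, a lower number a stronger inhibitor), compound 1 gives 1740 nM. Two further entries exist without a single number. Compound 2 `O=c1cc(-c2ccccc2)oc2c(OCCCCNC3CCCCC3)c(O)cc(O)c12` has no result reported in this assay, its entry reading "not determined" (no result reported), and compound 3 `COc1ccc(-c2cc(=O)c3c(O)cc(O)c(OC)c3o2)cc1` likewise has no result reported there, its entry reading "not determined" (no result reported), so nothing can be said about either beyond their structures. Among the compounds with values here, with only one measured point, compound 1 stands alone and no step between measured compounds can be read from the data.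

Compound 4 `COc1c(OCCCCN2CCN(C)CC2)cc(O)c2c(=O)cc(-c3ccccc3)oc12` is the next entry to be measured. It differs from compound 1 by methyl in place of hydrogen on an amine nitrogen in a ring. Nothing else in the two structures changes, and the shared core is kept intact.

Within the data shown here, with no measured step to lean on, the expectation rests on the small size of the change and on the one value available. Compound 4 is expected to sit close to compound 1, with the step from compound 1 to compound 4 estimated at a 1.1-fold lower number from compound 1 to compound 4 (0.04 log units; within the scatter) in this assay, that is, no step beyond the usual scatter in either direction. On that basis, compound 4 is estimated at 1600 nM in this assay, within a range of 700 nM to 3600 nM.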

Compound 4, half-maximal inhibitory concentration: 1500 nM
For compound 4 the middle estimate is 1.1-fold (0.03 log units) above the measured one; the measured number falls inside the stated range.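

Going by these compounds alone, the first measured step falls on the amine nitrogen of the six-membered ring: in this assay, going from piperazin-1-yl to 4-methylpiperazin-1-yl gives a 1.2-fold lower number from compound 1 to compound 4 (0.06 log units; within the scatter). The lone value for compound 1 could say nothing about this position, whereas this pair shows that a methyl in place of hydrogen on that ring nitrogen leaves the number inside the usual scatter, so the two compounds cannot be told apart in this read-out. No measured information bears on this result, and the step comes with no explanation.

From the compounds shown here alone, a single methyl is a small probe, so it remains open whether a larger group on the same nitrogen, such as a benzyl or an acetyl, would give a step beyond the scatter, and the same holds for a morpholine in place of the ring or a longer chain carrying it. The pair also rests on one cell line and one read-out, so it cannot show whether the absence of a step beyond the scatter would hold on a different core, such as those of compound 2 and compound 3, which have no number to compare.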